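This account rests on a few compounds, and the source may have more. Where it says the series, first, only, none or still open, it means among the compounds named here.

Compound 1 `COc1cc(Oc2cccc(Nc3ccccc3)c2)cc(OC)c1CNCc1ccc(Cl)cc1` carries a (4-chlorobenzyl)amino group on a saturated chain carbon bound to an aromatic carbon of the shared core. In a functional assay on HT-29 cells (Homo sapiens) for inhibition, read by MTT assay, with a stated time of 72 h (on this read-out higher numbers stand for weaker inhibition and lower numbers for stronger inhibition), compound 1 gives 3350 nM. Compound 2 `CCN1CCN(Cc2c(OC)cc(Oc3cccc(Nc4ccccc4)c3)cc2OC)CC1` carries a 4-ethylpiperazin-1-yl group at the same place. In this assay compound 2 reaches only a limit, > 20000 nM, so its true number is not known. The change from compound 1 to compound 2 went with an at least 5.9-fold higher number from compound 1 to compound 2 (0.77 log units; beyond the scatter); the size of that step is bounded by the limit (the limit of > 20000 nM in this assay, at which 1 of the 2 values shown sits).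

Compound 3 `COc1cc(Oc2cccc(Nc3ccccc3)c2)cc(OC)c1CNCc1ccc(O)cc1` has not yet been measured in this assay. It differs from compound 2 by (4-hydroxybenzyl)amino in place of 4-ethylpiperazin-1-yl on a saturated chain carbon bound to an aromatic carbon. This change largely reverses the step from compound 1 to compound 2, restoring a benzylamino group, with a hydroxyl in place of the chlorine on its ring.

Since the benzylamino compound 1 gave 3350 nM, compound 3 is expected to return to a number near that one, which means an expected step of an at least 4.0-fold lower number from compound 2 to compound 3 (0.60 log units; beyond the scatter). Compound 3 is therefore estimated at 5000 nM, with a likely range from 1500 nM to 20000 nM.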

Compound 3, half-maximal inhibitory concentration: 2180 nM
Compound 3: middle estimate off by 2.3-fold (0.36 log units), on the high side; low and high end bracket the measured number.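

Replacing the 4-ethylpiperazin-1-yl group with (4-hydroxybenzyl)amino on the saturated chain carbon goes with an at least 9.1-fold lower number from compound 2 to compound 3 (0.96 log units; beyond the scatter) in this assay, so the gain seen with a benzylamino group is not confined to the (4-chlorobenzyl)amino group of compound 1. Compound 2 sits at a limit, so this step has a bound rather than an exact size: the limit of > 20000 nM in this assay, at which 1 of the 3 values shown sits. Between the two benzylamino compounds, hydroxy in place of chloro on the aromatic carbon goes with a 1.5-fold lower number from compound 1 to compound 3 (0.19 log units; within the scatter), so this assay does not separate these two ring substituents.

The compounds shown leave open whether the difference from compound 2 depends on the benzyl ring or on the open-chain amine, which an unsubstituted benzylamino group, a dimethylamino group or a piperazine without its ethyl group could help to separate. As far as these compounds go, it also remains open whether a methoxy group or a carboxylic acid on the benzyl ring would keep the number in the same range as the chloro and hydroxy groups.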